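A few compounds are considered here, and "the series" means these few. Any claim that something is new, unique, unknown or untested is made for them only; others in the source may bear on it.

The study concerns two measured hydroxamic acids and one further compound that is still to be tested. Compound 1 `O=C(CCCCC[C@H](NC(=O)c1ccc(Br)cc1)C(=O)Nc1ccc(-c2ccccc2)cc1)NO` and compound 2 `CN(C)c1ccc(C(=O)N[C@@H](CCCCCC(=O)NO)C(=O)Nc2cccc3cccnc23)cc1` were both run in a functional assay on COLO 205 cells (Homo sapiens) for antiproliferative activity; on this read-out lower numbers stand for stronger inhibition and higher numbers for weaker inhibition. In this assay compound 1 gives 272 nM, and compound 2 gives 223 nM. Compound 2 shows the lowest of the two numbers, but its nearest neighbour, compound 1, lies within the scatter of it, so the two cannot be told apart on potency.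

Compound 3 `O=C(/C=C/c1ccccc1)N[C@@H](CCCCCC(=O)NO)C(=O)Nc1cccc2cccnc12` keeps the rest of the structure of compound 2 and changes only the cap on the carbonyl carbon: 2-phenylethenyl in place of 4-(dimethylamino)phenyl on a carbonyl carbon. Among the compounds with values here, no step between measured compounds is available to guide this change. Compound 3 is expected to show a step of a 1.2-fold lower number from compound 2 to compound 3 (0.09 log units; within the scatter) in this assay, modest and in favour of stronger inhibition, since the rest of the molecule is unchanged. The estimate for compound 3 in this assay is 180 nM, in the range from 70 nM to 450 nM.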

Compound 3, half-maximal inhibitory concentration: 141 nM
The estimate for compound 3 lay 1.3-fold (0.11 log units) above the measured number; measured number inside the range.
By their numbers in this assay, from the lowest: compounds 3, 2 and 1 (each within the scatter of the next).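

In this assay the exchange of 4-(dimethylamino)phenyl for 2-phenylethenyl on a carbonyl carbon gives a 1.6-fold lower number from compound 2 to compound 3 (0.20 log units; within the scatter) and so stays inside what repeated measurements can separate. Within the data shown here, this is the first step that can be read at this position, since compounds 1 and 2 differ in more than one place. It shows that here the cap can lose its nitrogen and gain a double bond outside aromatic rings with no change that can be told from the scatter, and no measurement is at hand that would explain this result.

On these data alone, whether the double bond matters remains open, as the saturated 2-phenylethyl cap would test. Also open, as far as these compounds go, is how this position would respond to a cap carrying a carboxylic acid or a primary amine.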